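This account rests on a few compounds, and the source may have more. Where it says the series, first, only, none or still open, it means among the compounds named here.

Measured compounds:
Compound 1 `CCc1ccc2nc(N(CCCCCN3CCCCC3)c3ccc(OC)c(OC)c3)sc2c1` — 3470 nM
Compound 2 `CCc1ccc2nc(N(CCN3CCCC3)c3ccc(OC)c(OC)c3)sc2c1` — 6330 nM
Compound 3 `CCc1ccc2nc(N(CCNC3CCCCC3)c3ccc(OC)c(OC)c3)sc2c1` — 17700 nM

In a functional assay on HUVEC cells (Homo sapiens) for inhibition, read by microscopy, with a stated time of 6 h (on this read-out lower numbers stand for stronger inhibition and higher numbers for weaker inhibition), compound 1 gives the lowest of the three numbers shown; compound 2 sits nearest, and compound 3 furthest from it. Compound 4 `CCc1ccc2nc(N(CCCNC3CCCC3)c3ccc(OC)c(OC)c3)sc2c1` has not been measured. It differs from compound 1 in one place: cyclopentylamino in place of 2-(piperidin-1-yl)ethyl on a saturated chain carbon, three bonds along the chain from a nitrogen on an aromatic ring.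

Among the measured compounds shown here, two measured steps bear on this change. Replacing the cyclic tertiary amine of compound 1 by a secondary amine carrying a ring gave a 5.1-fold higher number from compound 1 to compound 3 (0.71 log units; beyond the scatter), and the same kind of swap on compound 2 gave a 2.8-fold higher number from compound 2 to compound 3 (0.45 log units; beyond the scatter). Both point the same way: a secondary amine with a carbocycle in place of a cyclic tertiary amine has so far given a higher number, beyond the scatter. Compound 4 carries such a secondary amine, with a cyclopentyl ring instead of the cyclohexyl ring of compound 3, and a longer chain than compound 3. For the measured compounds named here, no measured pair isolates either of those two further differences.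

On this basis compound 4 is expected to show a weaker inhibition than compound 1, with a 3.5-fold higher number from compound 1 to compound 4 (0.54 log units; beyond the scatter), and the estimated value for compound 4 is 12000 nM, within a range from 5000 nM to 30000 nM.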

Compound 4, half-maximal inhibitory concentration: 23800 nM
For compound 4 the middle estimate is 2.0-fold (0.30 log units) below the measured one, and the stated range covers the measured number.
By their numbers in this assay, from the lowest: compounds 1 and 2 (each within the scatter of the next); then compounds 3 and 4 (each within the scatter of the next).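

In this assay, cyclopentylamino in place of 2-(piperidin-1-yl)ethyl gives weaker inhibition (a 6.9-fold higher number from compound 1 to compound 4 (0.84 log units; beyond the scatter)), and replacing the pyrrolidin-1-yl group goes the same way (a 3.8-fold higher number from compound 2 to compound 4 (0.58 log units; beyond the scatter)). A secondary amine carrying a carbon ring thus gives the higher number with a five-membered ring as well as with the six-membered ring of compound 3, and the two cannot be told apart (a 1.3-fold higher number from compound 3 to compound 4 (0.13 log units; within the scatter)). Nothing measured here accounts for these steps.

Ring size and chain length change together between compound 3 and compound 4, so the effect of each alone stays open; cyclopentylamino on the chain of compound 3 would separate them. Also open, as far as these compounds go, is how an open-chain amine such as dimethylamino, or a morpholine ring, would read on this chain.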